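Amide variation on the pyrazole-linked dihydroxyheptanoic acid series

This account rests on a few compounds, and the source may have more. Where it says the series, first, only, none or still open, it means among the compounds named here.

Measured so far:
Compound 1 `CC(C)c1c(C(=O)NCc2ccccn2)nn(-c2ccc(F)cc2)c1OC[C@@H](O)C[C@@H](O)CC(=O)O` — 25 nM
Compound 2 `CC(C)c1c(C(=O)NCc2ccc(Cl)cc2)nn(-c2ccc(F)cc2)c1OC[C@@H](O)C[C@@H](O)CC(=O)O` — 6.7 nM

Both compounds were tested in an assay on microsomes from liver for inhibition of 3-hydroxy-3-methylglutaryl-coenzyme A reductase (Rattus norvegicus); a lower number here means a stronger inhibitor, a higher number a weaker inhibitor. Compound 2 holds the lowest number of the two; the only other measured point is compound 1, and the step of a 3.7-fold lower number from compound 1 to compound 2 (0.57 log units; beyond the scatter) separates them, so compound 2 is set apart by a clear margin. Among the compounds with values here, that single step is all that the series so far says about the amide end, and it shows that exchanging the aromatic ring on the saturated chain carbon bound to the amide-type nitrogen is enough to move the number beyond the scatter.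

Compound 3 `CC(C)c1c(C(=O)N(C)[C@H](C)c2ccccc2)nn(-c2ccc(F)cc2)c1OC[C@@H](O)C[C@@H](O)CC(=O)O` is not yet measured. Relative to compound 2 the change is methyl(1-phenylethyl)amino in place of (4-chlorobenzyl)amino on a carbonyl carbon. Two things happen at once: the chlorine on the aromatic ring is gone, and the (4-chlorobenzyl)carbamoyl becomes a methyl(1-phenylethyl)carbamoyl with no hydrogen-bond donor left. Within the data shown here, no measured pair touches either of these changes directly; the step from compound 1 to compound 2 only shows the amide substituent is sensitive. A modest step, most likely toward a higher number, is expected in this assay, and the estimate for compound 3 is 25 nM, within 7 nM to 90 nM, corresponding to a 3.7-fold higher number from compound 2 to compound 3 (0.57 log units; beyond the scatter).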

Compound 3, half-maximal inhibitory concentration: 21 nM
Compound 3: the middle estimate sits 1.2-fold (0.08 log units) above what was measured; low and high end bracket the measured number.
By their numbers in this assay, from the lowest: compound 2; then compounds 3 and 1 (each within the scatter of the next).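

In this assay, the amide position still gives an inhibitor without the amide hydrogen, although methyl(1-phenylethyl)amino in place of (4-chlorobenzyl)amino comes with a 3.1-fold higher number from compound 2 to compound 3 (0.50 log units; beyond the scatter). Set against the amide of compound 1, the new group gives a 1.2-fold lower number from compound 1 to compound 3 (0.08 log units; within the scatter), so two quite different amide substituents stand level and only the (4-chlorobenzyl)amino group of compound 2 is set apart. The step from compound 2 changes the chlorine, the amide hydrogen, the added methyl and the stereocentre together, so it cannot be assigned to any one of them, and no measurement beyond these numbers bears on why the values fall as they do.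

Still open is how the step divides among these changes: plain benzylamino would isolate the chlorine, while (1-phenylethyl)amino would keep the amide hydrogen with the branched chain. Also open, on these data alone, are the opposite configuration of the 1-phenylethyl stereocentre and a methyl(4-chlorobenzyl)amino group, which would pair the chlorine with the methylated nitrogen.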